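A few compounds are considered here, and "the series" means these few. Any claim that something is new, unique, unknown or untested is made for them only; others in the source may bear on it.

Measured so far in a physicochemical assay for solubility, at pH 2; a higher number here means a more soluble compound, a lower number a less soluble compound:
Compound 1, `CNc1nc(NCCCN(C)C)c2sc(-c3ccc(N)cc3)cc2n1`: > 100 ug/mL, a limit of the assay rather than a number.
Compound 2, `CNc1nc(NCCCN(C)C)c2sc(-c3cccc(C#N)c3)cc2n1`: > 100 ug/mL, likewise a limit of the assay, not a number.

Compound 2 therefore stands at the upper end of what this assay reports. Among the compounds with values here, the one measured step, a step that the two limits leave unreadable from compound 1 to compound 2, cannot be sized, since both values sit at the same point (the limit of > 100 ug/mL in this assay, at which 2 of the 2 values shown sit). Compound 3, `CNc1nc(NCCCN(C)C)c2sc(-c3ccc(OC)nc3)cc2n1`, differs from compound 2 by 6-methoxypyridin-3-yl in place of 3-cyanophenyl on an aromatic carbon. Within the data shown here, no measured step gives a size for such a change, so the step is estimated only as a step that the limit leaves unreadable from compound 2 to compound 3, with another limit the likely outcome. Compound 3 is estimated at 150 ug/mL, in the range 70 ug/mL to 400 ug/mL.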

Compound 3, solubility: > 100 ug/mL
Compound 3: only a limit was reported; the forecaster's own chance of this, stated with the estimate: 75%; the middle value does not contradict the limit.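

Compound 1, compound 2 and compound 3 all give only a limit of the assay, not a number, so no step between them can be read: the limit of > 100 ug/mL in this assay, at which 3 of the 3 values shown sit.

Going by these compounds, how far each compound lies past that limit, and whether exchanging these groups changes the read-out at all, stays open.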